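Pyrrolidin-2-yl to pyridin-3-yl: expected loss of antiproliferative activity

A few compounds are considered here, and "the series" means these few. Any claim that something is new, unique, unknown or untested is made for them only; others in the source may bear on it.

Compound 1 `COc1ccc(-c2noc(-c3ccncc3)n2)cc1OC1CCCC1` gives > 1000000 nM in a functional assay on HCT-116 cells (Homo sapiens) for antiproliferative activity, read by MTT assay, with a stated time of 24 h (on this read-out higher numbers stand for weaker inhibition and lower numbers for stronger inhibition), which is a limit of the assay. Compound 3 `COc1cc(-c2noc(-c3ccncc3)n2)ccc1OCc1ccccc1` gives > 1000000 nM in this assay, also a limit. Both carry pyridin-4-yl, and the limit of > 1000000 nM in this assay, at which 2 of the 3 values shown sit, is the ceiling on the evidence so far. For the measured compounds named here, compound 2 `COc1ccc(-c2noc(C3CCCN3)n2)cc1OC1CCCC1` gives 185000 nM, the only true number.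

Compound 4 `COc1ccc(-c2noc(-c3cccnc3)n2)cc1OC1CCCC1` differs from compound 2 at one place: pyridin-3-yl in place of pyrrolidin-2-yl on an aromatic carbon. Pyridin-3-yl stands in place of pyrrolidin-2-yl on an aromatic carbon. Going by the values given here, no pyridin-3-yl compound has been measured yet.

The closest measured step is an at least 5.4-fold lower number from compound 1 to compound 2 (0.73 log units; beyond the scatter), a bound rather than an exact size. It swaps pyridin-4-yl for pyrrolidin-2-yl at this same place. Compound 4 returns to a pyridine ring, so most of that step is expected to reverse, towards higher numbers. The expected change is a 3.8-fold higher number from compound 2 to compound 4 (0.58 log units; beyond the scatter). A reading at the limit would fit this expectation. For compound 4 the estimated value is 700000 nM, with an expected range from 250000 nM to 1500000 nM.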

Compound 4, half-maximal inhibitory concentration: > 1000000 nM
Compound 4: only a limit was reported; the forecaster's own chance of this, stated with the estimate: 60%; middle value at least 1.4-fold (0.15 log units) from the limit.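

In this assay pyridin-3-yl in place of pyrrolidin-2-yl gives an at least 5.4-fold higher number from compound 2 to compound 4 (0.73 log units; beyond the scatter) and that size is a bound, as compound 4 sits at a limit. Together with compound 1, this shows that neither pyridin-4-yl nor pyridin-3-yl at this carbon of the shared core gives a true number, so moving the ring nitrogen of the pyridine does not restore a measurable value. The step between compound 1 and compound 4 cannot be read, and the two pyridine attachments cannot be ordered, with the series standing thus: the limit of > 1000000 nM in this assay, at which 3 of the 4 values shown sit.

Open, on these data alone, is whether the measurable value of compound 2 needs a ring at all, which an open-chain aminomethyl group or piperidin-2-yl at this carbon would address. Also open, as far as these compounds go, is how a carboxylic acid at this carbon would read.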